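The source may report more compounds than this note shows. Statements on the series, on what has been measured and on what is new or still open speak of the compounds shown alone.

In a functional assay on HeLa cells (Homo sapiens) for cytotoxicity, read by WST assay, with a stated time of 48 h (a higher number here means a weaker inhibitor, a lower number a stronger inhibitor), compound 1 (`COC[C@H](C(C)C)C(c1ccc(O)c(OC)c1)c1ccc(O)c(OC)c1`) gives 76000 nM, compound 2 (`COc1cc(C(c2ccc(O)c(OC)c2)[C@H](C)C(C)C)ccc1O`) gives 16000 nM, and compound 3 (`COc1cc(C(c2ccc(O)c(OC)c2)[C@H](CC(C)C)C(C)C)ccc1O`) gives 8200 nM. Two of these three numbers sit together at the low end, with compound 3 among them, and the data show a 2.0-fold lower number from compound 2 to compound 3 (0.29 log units; within the scatter). Against the remaining number they show a 9.3-fold lower number from compound 1 to compound 3 (0.97 log units; beyond the scatter).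

Compound 4 (`COc1cc(C(c2ccc(O)c(OC)c2)[C@@H](CF)C(C)C)ccc1O`) carries 1-(fluoromethyl)-2-methylpropyl in place of 1-isopropyl-3-methylbutyl on a saturated chain carbon bound to two aromatic carbons. The measured steps that bear on this change were made on a saturated chain carbon, three bonds along the chain from two aromatic carbons. There, hydrogen in place of methoxy gave a 4.8-fold lower number from compound 1 to compound 2 (0.68 log units; beyond the scatter), while isopropyl in place of hydrogen gave a 2.0-fold lower number from compound 2 to compound 3 (0.29 log units; within the scatter). Going by the values given here, no fluorine-bearing compound has been measured, so the comparison is indirect. The number for compound 4 is expected to land nearer compound 2, at 16000 nM, than compound 1, at 76000 nM. A modest rise in this assay is therefore expected, estimated as a 2.7-fold higher number from compound 3 to compound 4 (0.43 log units; beyond the scatter). Compound 4 is estimated at 22000 nM, with an expected range from 8000 nM to 60000 nM.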

Compound 4, half-maximal inhibitory concentration: 41000 nM
Compound 4: the middle estimate sits 1.9-fold (0.27 log units) below what was measured; the measured number falls inside the stated range.
By their numbers in this assay, from the lowest: compounds 3 and 2 (each within the scatter of the next); then compounds 4 and 1 (each within the scatter of the next).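

In this assay, the fluorine-bearing chain on this saturated chain carbon bound to two aromatic carbons does not join the low pair: the data show a 5.0-fold higher number from compound 3 to compound 4 (0.70 log units; beyond the scatter) and also a 2.6-fold higher number from compound 2 to compound 4 (0.41 log units; beyond the scatter) when 1-(fluoromethyl)-2-methylpropyl replaces the 1,2-dimethylpropyl chain. Against the 1-(methoxymethyl)-2-methylpropyl chain the data show a 1.9-fold lower number from compound 1 to compound 4 (0.27 log units; within the scatter) so fluorine and methoxy at the end of this branch cannot be told apart here, and the four compounds fall into two groups, with compound 1 and compound 4 on the high side and compound 2 and compound 3 on the low side, with no compound going against that split. Nothing available here explains why the chains divide in this way.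

As far as these compounds go, whether a hydroxymethyl, an aminomethyl or a chloromethyl branch would fall with compound 1 and compound 4 or with compound 2 and compound 3 remains open. So does whether a longer fluoroalkyl chain, which would add carbon alongside the fluorine, would stay on the high side or move towards compound 3.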